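Swapping 5-bromopyridin-3-yl for 3-chlorophenyl on compound 1

The source may report more compounds than this note shows. Statements on the series, on what has been measured and on what is new or still open speak of the compounds shown alone.

Compound 1 `Nc1ccccc1NC(=O)c1ccc(NC(=S)NCc2cncc(Br)c2)cc1` was tested in an assay on isolated protein for inhibition of Nicotinamide phosphoribosyltransferase (Homo sapiens), read by fluorescence, with stated times of 5 min and 15 min (a higher number here means a weaker inhibitor, a lower number a stronger inhibitor), and there it gives only a limit, > 2000 nM. Compound 2 `Nc1ccccc1NC(=O)c1ccc(NC(=O)NCc2ccc(Cl)nc2)cc1` likewise reaches only a limit in this assay, > 2000 nM. Compound 3 `Nc1ccccc1NC(=O)c1ccc(Cn2cc(-c3ccc(NC(=O)NCc4cccnc4)cc3)nn2)cc1`, of a different build, gives 18 nM in this assay. Two of the three values therefore sit at the limit, as the limit of > 2000 nM in this assay, at which 2 of the 3 values shown sit, records, and compound 1 stands among them with no number of its own. Compound 4 `Nc1ccccc1NC(=O)c1ccc(NC(=S)NCc2cccc(Cl)c2)cc1` differs from compound 1 in one place: 3-chlorophenyl in place of 5-bromopyridin-3-yl on a saturated chain carbon bound to an amide-type nitrogen. Among the measured compounds shown here, no measured pair shows what such a swap does, so the expected step is none beyond the scatter, a step that the limit leaves unreadable from compound 1 to compound 4. Compound 4 is thus estimated at 3000 nM, within 1500 nM to 8000 nM, most likely reported again only as a limit.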

Compound 4, half-maximal inhibitory concentration: > 2000 nM
Compound 4: a limit, no number (the forecaster's own chance of this, stated with the estimate: 75%); the middle value does not contradict the limit.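

No step can be read from compound 1 to compound 4, because both stop at the same limit: the limit of > 2000 nM in this assay, at which 3 of the 4 values shown sit. As far as these compounds go, whether 3-chlorophenyl in place of 5-bromopyridin-3-yl changes inhibition at all remains open.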